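Phenyl Addition on a Second Core: Stomach Inhibition

A few compounds are considered here, and "the series" means these few. Any claim that something is new, unique, unknown or untested is made for them only; others in the source may bear on it.

Measured compounds:
compound 1, `N=C(S)CCn1nc(-c2ccccc2)ccc1=S`, gives 62.3%
compound 2, `N=C(S)CCn1ncccc1=S`, gives 50%
compound 3, `CC(CC(=N)S)n1ncccc1=O`, gives 38.8%

All three were tested in a functional assay on the whole organism (stomach) for inhibition, with Rattus norvegicus as the target, at a dose of 100 mg/kg by the intraduodenal route; on this read-out lower numbers stand for less inhibition and higher numbers for more inhibition at the one dose given (going by the name of the read-out). Among the measured compounds shown here, the one change already measured is phenyl in place of hydrogen on an aromatic carbon; it gave a number 12.3 percentage points higher from compound 2 to compound 1 (beyond the scatter). Compound 3 is built on a different core from compound 2, and the difference between the two cores is not broken down here; compound 3 gives the lowest of the three numbers.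

Compound 4, `CC(CC(=N)S)n1nc(-c2ccccc2)ccc1=O`, is not yet measured. It differs from compound 3 by phenyl in place of hydrogen on an aromatic carbon. For the measured compounds named here, this is the same kind of change as the one from compound 2 to compound 1, but not the same: in compound 4 the new phenyl sits meta to a group of 6 heavy atoms, whereas in compound 1 it sits meta to a group of 5 heavy atoms.

Because compound 2 to compound 1 gave a number 12.3 percentage points higher from compound 2 to compound 1 (beyond the scatter), a gain of similar size is expected here, namely a number 10.2 percentage points higher from compound 3 to compound 4 (beyond the scatter). Compound 4 is therefore estimated at 49%, between 37% and 62%.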

Compound 4, a percentage reported as inhibition, in the whole organism at one dose (the size of the read-out at that dose, not a potency): 15.5%
Beside the measured number, compound 4's estimate is 33.5 percentage points above it; measured number below the stated range.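

Putting phenyl in place of hydrogen on an aromatic carbon gives a number 23.3 percentage points lower from compound 3 to compound 4 (beyond the scatter) in this assay. On these two cores the change therefore does not carry over, and its result on one core would not have served as a guide to its result on the other, not even in direction: the same change on two cores in this assay, a number 12.3 percentage points higher (beyond the scatter) from compound 2 to compound 1 and a number 23.3 percentage points lower (beyond the scatter) from compound 3 to compound 4, 35.6 percentage points apart, beyond the scatter of two such steps
The cores of compound 2 and compound 3 differ in more than one place, and these four compounds do not show which of those differences goes with the reversal, nor do two pairs give a rule for any further core.

The compounds shown leave open whether a chlorine atom or a methoxy group on the same ring carbon would follow the phenyl on each core. They also leave open how either core would respond with a carboxylic acid in place of the group at the end of the chain.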